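Chalcone Extension and a Nitro-for-Bromo Swap

The source may report more compounds than this note shows. Statements on the series, on what has been measured and on what is new or still open speak of the compounds shown alone.

Compound 1 `CC(=O)c1ccc(NC(=O)CSC(=S)N[C@H]2CCOC2=O)cc1` gives 99400 nM in a functional assay on MGC-803 cells (Homo sapiens) for cytotoxicity, read by MTT assay, with a stated time of 72 h; on this read-out higher numbers stand for weaker inhibition and lower numbers for stronger inhibition. Compound 2 `O=C(CSC(=S)N[C@H]1CCOC1=O)Nc1ccc(C(=O)/C=C/c2ccc(Br)cc2)cc1` gives 19600 nM, and the step of a 5.1-fold lower number from compound 1 to compound 2 (0.71 log units; beyond the scatter) places compound 2 lowest of the two numbers shown, with compound 1 its only neighbour. Compound 3 `O=C(CSC(=S)N[C@H]1CCOC1=O)Nc1ccc(C(=O)/C=C/c2ccc([N+](=O)[O-])cc2)cc1` carries nitro in place of bromo on an aromatic carbon. For the measured compounds named here, the single measured step replaced a methyl on the carbonyl carbon, not a group on the distal aromatic ring, so nothing measured speaks directly to this exchange. Compound 3 is therefore expected to stay within the scatter of compound 2, a step of a 1.3-fold lower number from compound 2 to compound 3 (0.12 log units; within the scatter), estimated at 15000 nM (range 5000 nM to 45000 nM).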

Compound 3, half-maximal inhibitory concentration: 29400 nM
Estimate against measurement, compound 3: 2.0-fold (0.29 log units) below; the measured number falls inside the stated range.
By their numbers in this assay, from the lowest: compounds 2 and 3 (each within the scatter of the next); then compound 1.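

On this aromatic carbon, bromo and nitro cannot be told apart in this assay: the step of a 1.5-fold higher number from compound 2 to compound 3 (0.18 log units; within the scatter) stays small, even though the entering group is larger by the heavy-atom count. The lower number relative to the methyl-bearing compound also holds with nitro, as the step of a 3.4-fold lower number from compound 1 to compound 3 (0.53 log units; beyond the scatter) shows, so it is not confined to the bromo compound. No evidence on the origin of these steps is available.

As far as these compounds go, whether an amine or a methoxy group on that aromatic carbon would also stay within the scatter of compound 2 remains open. So does the reading of an unsubstituted phenyl on the ethenyl chain.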